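Fluoro in place of methylsulfanyl: working notes on the series

The compounds below may be only part of what the source reports. "The series", "measured", "known", "first", "only" and "open" are said of these compounds alone.

In an ADME assay on HepG2 cells (Homo sapiens) for cytotoxicity, with a stated time of 72 h (on this read-out lower numbers stand for an effect already at smaller amounts and higher numbers for an effect only at larger amounts of compound), compound 3 `CSc1ccc(NC(=O)Nc2cc(C)nc3ccccc23)cc1` gives 16000 nM and compound 2 `Cc1cc(NC(=O)Nc2ccc(Cl)c(Cl)c2)c2ccccc2n1` gives 17000 nM, two values within the scatter of each other although the two compounds carry different substituents. Compound 1 `Cc1cc(NC(=O)Nc2ccccc2OC(F)(F)F)c2ccccc2n1` reports only a limit, > 25000 nM. Compound 4 `Cc1cc(NC(=O)Nc2ccc(F)cc2)c2ccccc2n1` has fluoro in place of methylsulfanyl on an aromatic carbon, para to a large group (fluoro in place of methylsulfanyl on an aromatic carbon). Among the compounds with values here, no measured pair in this assay differs in one place only, so the size of this change has no direct precedent. The expected step of a 1.3-fold higher number from compound 3 to compound 4 (0.10 log units; within the scatter) is small, towards a higher number, and may stay within the scatter. For compound 4 the estimate is 20000 nM, with an expected range of 12000 nM to 25000 nM.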

Compound 4, half-maximal effective concentration: > 25000 nM
Compound 4 ended at the assay's limit; the forecaster's own chance of this, stated with the estimate: 35%; at least 1.2-fold (0.09 log units) between middle value and limit.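

In this assay, within the data shown here, fluoro in place of methylsulfanyl on an aromatic carbon, para to a large group, gives the only one-place comparison: an at least 1.5-fold higher number from compound 3 to compound 4 (0.19 log units; that floor lies within the scatter). As far as these compounds go, this figure is a floor, so the change shows no move towards a lower number, while its full size remains unknown. The reading stops at the assay's limit: the limit of > 25000 nM in this assay, at which 2 of the 4 values shown sit.

From the compounds shown here alone, whether a different group at this position, such as an amine or a carboxylic acid, would give a number below that limit remains open. This single step also cannot show whether the same change would behave alike on another compound.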